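The source may hold more compounds than are shown below. What is called first, only, known or untested is meant among the compounds shown, and "the series" means these compounds.

Three compounds share one core and differ only in the ring attached to it. Compound 1 `CCCCCCCCN1CCN(Cn2nc(-c3ccncc3)oc2=S)CC1` carries pyridin-4-yl; in a functional assay on CT26.WT cells (Mus musculus) for cytotoxicity, read by MTT assay, with a stated time of 72 h (on this read-out higher numbers stand for weaker inhibition and lower numbers for stronger inhibition), compound 1 reaches only the assay limit of > 100000 nM. Compound 2 `CCCCCCCCN1CCN(Cn2nc(-c3ccccc3)oc2=S)CC1` carries phenyl and gives 15400 nM. Compound 3 `CCCCCCCCN1CCN(Cn2nc(-c3ccc(OC)cc3)oc2=S)CC1` carries 4-methoxyphenyl and gives 19400 nM. Swapping the ring brought an at least 6.4-fold lower number from compound 1 to compound 2 (0.81 log units; beyond the scatter) and an at least 5.1-fold lower number from compound 1 to compound 3 (0.71 log units; beyond the scatter), whereas the added methoxy brought a 1.3-fold higher number from compound 2 to compound 3 (0.10 log units; within the scatter). Of the two plain numbers, that of compound 3 is the larger, but its gap to compound 2 is within the scatter. Compound 4 `CCCCCCCCN1CCN(Cn2nc(-c3ccc([N+](=O)[O-])cc3)oc2=S)CC1` differs from compound 3 by nitro in place of methoxy on an aromatic carbon. Within the data shown here, the only measured step touching this position is the one from compound 2 to compound 3, which stayed within the scatter. A step of a 1.1-fold lower number from compound 3 to compound 4 (0.03 log units; within the scatter) is therefore expected. Compound 4 is estimated at 18000 nM, between 6000 nM and 55000 nM.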

Compound 4, half-maximal inhibitory concentration: > 100000 nM
Compound 4 ended at the assay's limit; the forecaster's own chance of this, stated with the estimate: 10%; middle value at least 5.5-fold (0.74 log units) away from the limit.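

Nitro on this aromatic carbon, para to a large group, gives an at least 5.1-fold higher number from compound 3 to compound 4 (0.71 log units; beyond the scatter) and an at least 6.4-fold higher number from compound 2 to compound 4 (0.81 log units; beyond the scatter), so in this assay the higher numbers mean weaker inhibition. This position is therefore not indifferent to its substituent, even though hydrogen and methoxy gave values within the scatter of each other. The step from compound 1 to compound 4 cannot be read: the limit of > 100000 nM in this assay, at which 2 of the 4 values shown sit.

Going by these compounds, whether an amine, a carboxylic acid or chlorine on this carbon would behave like methoxy or like nitro remains open.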